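The source may hold more compounds than are shown below. What is called first, only, known or untested is meant among the compounds shown, and "the series" means these compounds.

Compound 1, `Cc1ccc2nc(NC(=S)Nc3ccccc3)sc2c1`: in a functional assay on THP-1 cells (Homo sapiens) for cytotoxicity, read by MTT assay, with a stated time of 48 h (a higher number here means a weaker inhibitor, a lower number a stronger inhibitor), compound 1 gives > 50000 nM, which is a limit of the assay rather than a number.
Compound 2, `S=C(Nc1ccccc1)Nc1nc2ccccc2s1`: in this assay compound 2 gives 36500 nM.

Compound 2 holds the only number shown in this assay; the one further value is a limit (the limit of > 50000 nM in this assay, at which 1 of the 2 values shown sits). Among the compounds with values here, the step of an at least 1.3-fold lower number from compound 1 to compound 2 (0.13 log units; that floor lies within the scatter) is the single measured change, and its floor lies within the scatter, so it shows at most a weak loss from adding a methyl at that aromatic carbon.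

Compound 3, `CCOc1ccc2nc(NC(=S)Nc3ccccc3)sc2c1`, differs from compound 2 by ethoxy in place of hydrogen on an aromatic carbon. This is again a substituent entering at the same kind of position as the methyl of compound 1. The measured step from compound 1 to compound 2 therefore bears on it, and a step of similar or somewhat larger size toward a higher number is expected, so compound 3 is estimated at 55000 nM in this assay, within 25000 nM to 150000 nM, the expected step being a 1.5-fold higher number from compound 2 to compound 3 (0.18 log units; within the scatter).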

Compound 3, half-maximal inhibitory concentration: 43800 nM
Compound 3: the middle estimate sits 1.3-fold (0.10 log units) above what was measured, within the range that was stated.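

Within the data shown here, putting ethoxy in place of hydrogen on this aromatic carbon gives a 1.2-fold higher number from compound 2 to compound 3 (0.08 log units; within the scatter), and because both ends of this step are numbers, it is the first comparison at this position that is not bounded by a limit; in this assay, compound 2 and compound 3 cannot be told apart. Ethoxy in place of methyl gives an at least 1.1-fold lower number from compound 1 to compound 3 (0.05 log units; that floor lies within the scatter), so this change also shows no difference beyond the scatter. That step has only a floor, since the value of compound 1 is a limit and not a number: the limit of > 50000 nM in this assay, at which 1 of the 3 values shown sits.

From the compounds shown here alone, whether an amine, a carboxylic acid or a longer alkoxy chain at this carbon would move the number beyond the scatter remains open. Also open, going by these compounds, is whether ethoxy on another carbon of the same ring would read the same.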